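The compounds below may be only part of what the source reports. "The series", "measured", "known", "first", "only" and "open" are said of these compounds alone.

Measured so far in a functional assay on MCF7 cells (Homo sapiens) for cytotoxicity, read by MTT assay, with a stated time of 72 h; on this read-out lower numbers stand for stronger inhibition and higher numbers for weaker inhibition:
compound 1, `COc1cccc(/C=C2\CCC/C(=C\c3ccc(O)cc3)C2=O)c1OC`: > 20000 nM
compound 2, `COc1cc(/C=C2\CCC/C(=C\c3cccc(OC)c3OC)C2=O)ccc1O`: 11600 nM
compound 3, `COc1ccc(/C=C2\CCC/C(=C\c3ccc(Br)cc3)C2=O)cc1OC`: 6900 nM

The value of compound 1 is a limit of the assay, not a number. Compound 2 and compound 3 give numbers that sit within the usual scatter of each other, so neither can be ranked over the other. Compound 4, `COc1ccc(/C=C2\CCC/C(=C\c3cc(Cl)cc(Cl)c3)C2=O)cc1OC`, has not yet been measured. It differs from compound 3 in one place: 3,5-dichlorophenyl in place of 4-bromophenyl on a double-bonded chain carbon bound to a double-bonded ring carbon. Going by the values given here, the only measured step, an at least 1.7-fold lower number from compound 1 to compound 2 (0.23 log units; that floor lies within the scatter), concerns a methoxy group and says nothing about exchanging one halogen pattern for another. Among the compounds with values here, no measured step therefore bears on this change, and no shift beyond the scatter is expected. Compound 4 is estimated at 7000 nM, with a range from 2500 nM to 20000 nM, which means an expected step of a 1.0-fold higher number from compound 3 to compound 4 (0.01 log units; within the scatter).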

Compound 4, half-maximal inhibitory concentration: 3800 nM
Compound 4: middle estimate off by 1.8-fold (0.27 log units), on the high side; low and high end bracket the measured number.
By their numbers in this assay, from the lowest: compounds 4, 3 and 2 (each within the scatter of the next, the first and the last beyond it). At a limit, above all of these: compound 1.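

In this assay, 3,5-dichlorophenyl in place of 4-bromophenyl gives a 1.8-fold lower number from compound 3 to compound 4 (0.26 log units; within the scatter). This is the only halogen exchange shown at this place, and it shows that one more heavy atom and a different halogen pattern on this ring leave the number within what repeat measurements would give. Nothing measured here accounts for the step. The kind of halogen and the number of halogens change together, so their parts cannot be separated. A phenyl ring carrying an amine or a carboxylic acid at this place remains an open case.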